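The compounds below may be only part of what the source reports. "The series", "measured", "known", "first", "only" and "open" are said of these compounds alone.

Compound 1 `O=C(O)C1=Cc2ccccc2OC1(OCc1cc(-c2ccc([N+](=O)[O-])cc2)no1)C(F)(F)F` gives in a functional assay on HeLa cells (Homo sapiens) for inhibition, read by MTT assay, with a stated time of 24 h (a lower number here means a stronger inhibitor, a higher number a weaker inhibitor), only a limit, > 150000 nM.
Compound 2 `O=C(O)C1=Cc2ccccc2OC1(OCc1cc(-c2ccc(F)cc2F)no1)C(F)(F)F` gives in this assay only a limit, > 150000 nM.
Compound 3 `O=C(O)C1=Cc2ccccc2OC1(OCc1cc(-c2cccc(C(F)(F)F)c2)no1)C(F)(F)F` gives in this assay only a limit, > 150000 nM.

Compound 3 therefore stands where every measured compound stands: at the edge of what this assay can report, as the limit of > 150000 nM in this assay, at which 3 of the 3 values shown sit, shows, with no number inside the measurable range for any of the three.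

Compound 4 `COc1ccc(-c2cc(COC3(C(F)(F)F)Oc4ccccc4C=C3C(=O)O)on2)cc1` differs from compound 3 in one place: 4-methoxyphenyl in place of 3-(trifluoromethyl)phenyl on an aromatic carbon. The measured steps that swap the group on the same aromatic carbon are a step that the two limits leave unreadable from compound 1 to compound 2, a step that the two limits leave unreadable from compound 1 to compound 3 and a step that the two limits leave unreadable from compound 2 to compound 3; none of them can be read as a size or a direction, since every value behind them is a limit.

From this the expected step of a number no higher from compound 3 to compound 4 (the limit leaves the size open) is no readable change beyond the scatter, with the most likely outcome again a limit. For compound 4 the expected value in this assay is 150000 nM, within a range from 40000 nM to 400000 nM.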

Compound 4, half-maximal inhibitory concentration: > 150000 nM
Compound 4: no number, only a limit; the forecaster's own chance of this, stated with the estimate: 85%; the middle value lies on the limit itself.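

Compound 4 also gives only a limit, so its steps from compound 1, compound 2 and compound 3 cannot be read as a size or a direction: the limit of > 150000 nM in this assay, at which 4 of the 4 values shown sit. The compounds shown leave open whether changing the group at this place can bring any measurable inhibition in this assay.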